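Furan-3-yl to thiophen-3-yl in the series: working notes

The source may report more compounds than this note shows. Statements on the series, on what has been measured and on what is new or still open speak of the compounds shown alone.

Measured in a functional assay on A549 cells (Homo sapiens), read by MTT assay, with a stated time of 72 h; a higher number here means a weaker inhibitor, a lower number a stronger inhibitor:
- compound 1 `Nc1nc(N)c2c(-c3ccsc3)cn([C@@H]3O[C@H](CO)[C@@H](O)[C@H]3O)c2n1`: > 100000 nM
- compound 2 `Cc1nc(N)c2c(-c3ccoc3)cn([C@@H]3O[C@H](CO)[C@@H](O)[C@H]3O)c2n1`: > 20000 nM

Both entries are limits, not numbers. Compound 1 gives > 100000 nM, which is a limit. Compound 2 gives > 20000 nM, which is also a limit. Compound 2 therefore has no numeric value in this assay, and its standing is simply (the limit of > 20000 nM in this assay, at which 1 of the 2 values shown sits).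

Compound 3 `Cc1nc(N)c2c(-c3ccsc3)cn([C@@H]3O[C@H](CO)[C@@H](O)[C@H]3O)c2n1` is the next case. It has thiophen-3-yl in place of furan-3-yl on an aromatic carbon. Going by the values given here, the series offers no step between measured compounds, so the size of this change cannot be read from the data. No shift beyond the scatter is expected in this assay, and a further report of a limit is the likeliest outcome. This expectation rests on compound 2 with its > 20000 nM.

The estimated change is a step that the limit leaves unreadable from compound 2 to compound 3, which is expected to carry no clear direction. For compound 3 the expected value is 30000 nM, with an estimated range of 6000 nM to 100000 nM.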

Compound 3, half-maximal inhibitory concentration: > 20000 nM
Compound 3: only a limit was reported; the forecaster's own chance of this, stated with the estimate: 70%; the middle value lies beyond the limit too.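

In this assay compound 3 gives > 20000 nM, which is a limit. Compound 1, compound 2 and compound 3 all carry limits, so neither the step from compound 2 to compound 3 nor the step from compound 1 to compound 3 can be read. The compounds shown leave open whether either exchange, thiophen-3-yl for furan-3-yl or methyl for amino, changes the inhibitory concentration at all.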